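The source may report more compounds than this note shows. Statements on the series, on what has been measured and on what is new or still open speak of the compounds shown alone.

Of the compounds shown here, three have so far been measured in an assay on HEK293 cells for displacement of a labelled ligand from 5-hydroxytryptamine receptor 7 (Homo sapiens), read by scintillation counting, with a stated time of 1 h; a higher number here means a weaker inhibitor, a lower number a stronger inhibitor. Compound 1 `O=S(=O)(NCCCN1CCc2ccccc2C1)c1ccccc1` gives 270 nM in this assay. Compound 2 `NCCCN(CCN1CCc2ccccc2C1)S(=O)(=O)c1ccccc1` gives 3010 nM in this assay. Compound 3 `COc1ccccc1N1CCN(CCCCNS(=O)(=O)c2cnc3ccccc3c2)CC1` gives 79 nM in this assay, the lowest of the three numbers; its gap to compound 1 lies beyond the scatter, and its gap to compound 2 is wider still and also beyond the scatter.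

Compound 4 `COc1ccccc1N1CCN(CCCCNS(=O)(=O)c2ccc3ncccc3c2)CC1` has not yet been measured in this assay. It differs from compound 3 in one place: quinolin-6-yl in place of quinolin-3-yl on a sulfonyl sulfur. For the measured compounds named here, no measured pair shows what this change does, since compound 1 and compound 2 carry a different sulfonyl group altogether and no two of the three measured compounds differ in one place only. The two quinolinyl groups have the same atoms joined differently, so the step is expected to be modest rather than large. For compound 4 a small rise in the number, at the edge of the scatter, is expected: a 2.0-fold higher number from compound 3 to compound 4 (0.31 log units; beyond the scatter). Compound 4 is therefore estimated at 160 nM in this assay, with a range from 45 nM to 600 nM.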

Compound 4, inhibition constant: 132 nM
Compound 4: middle estimate off by 1.2-fold (0.08 log units), on the high side; measured number inside the range.
By their numbers in this assay, from the lowest: compounds 3 and 4 (each within the scatter of the next); then compound 1; then compound 2.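

For the compounds shown here, with quinolin-6-yl in place of quinolin-3-yl on a sulfonyl sulfur, this assay records a 1.7-fold higher number from compound 3 to compound 4 (0.22 log units; within the scatter), the first step that isolates a change in one place. The earlier compounds shown here could not show what this place tolerates, whereas this pair shows that two quinolinyl groups with the same atoms, joined differently, cannot be told apart here: the values of compound 3 and compound 4 lie within the usual scatter of each other, so neither group can be ranked above the other at this sulfonyl sulfur. No independent measurement accompanies the result that could say anything about what lies behind it.

The compounds shown leave open whether this insensitivity extends beyond these two quinolinyl groups, for instance to quinolin-8-yl, isoquinolin-5-yl or naphthalen-2-yl on the same sulfonyl sulfur, where a ring of carbon only would replace the nitrogen-bearing ring. They also leave open how much of the value depends on the rest of the shared core, such as the methoxy group or the length of the chain, which a shorter propyl or longer pentyl chain would test.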